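This account rests on a few compounds, and the source may have more. Where it says the series, first, only, none or still open, it means among the compounds named here.

In an assay on L cells for inhibition of Protein-serine O-palmitoleoyltransferase porcupine (Mus musculus), read by reporter gene assay, with a stated time of 24 h (on this read-out lower numbers stand for an effect already at smaller amounts and higher numbers for an effect only at larger amounts of compound), compound 1 `COc1ccc(-n2c(SCC(=O)Nc3nc4ccc(Cl)cc4s3)nc3c(c2=O)SCC3)cc1` gives 35 nM, compound 3 `O=C(CSc1nc2c(c(=O)n1-c1ccccc1)SCC2)Nc1nc2ccc(Cl)cc2s1` gives 40 nM, and compound 2 `COc1ccc(-n2c(SCC(=O)Nc3nc4ccc(C(F)(F)F)cc4s3)nc3c(c2=O)SCC3)cc1` gives 100 nM, the highest of the three numbers. Compound 4 `COc1ccccc1-n1c(SCC(=O)Nc2nc3ccc(C(F)(F)F)cc3s2)nc2c(c1=O)SCC2` differs from compound 2 in one place: 2-methoxyphenyl in place of 4-methoxyphenyl on an aromatic nitrogen. Of the two measured steps, only one touches this part of the molecule: a 1.1-fold higher number from compound 1 to compound 3 (0.06 log units; within the scatter), which shows that removing the methoxy altogether left the number essentially unchanged. The other step, a 2.9-fold higher number from compound 1 to compound 2 (0.46 log units; beyond the scatter), concerns the trifluoromethyl and does not bear on the methoxy. Shifting the methoxy is therefore expected to give a small step as well, namely no change at the digits printed from compound 2 to compound 4 (within the scatter). Compound 4 is estimated at 100 nM, with a likely range from 40 nM to 250 nM.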

Compound 4, half-maximal effective concentration: 30 nM
The estimate for compound 4 lay 3.3-fold (0.52 log units) above the measured number; the measured number lies below the stated range.
By their numbers in this assay, from the lowest: compounds 4, 1 and 3 (each within the scatter of the next); then compound 2.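

In this assay, the atoms stay the same and only the methoxy moves, from 4-methoxyphenyl to 2-methoxyphenyl, yet this gives a 3.3-fold lower number from compound 2 to compound 4 (0.52 log units; beyond the scatter). Where the methoxy sits on this ring therefore matters in the trifluoromethyl series, even though removing it in the chloro series gave only a 1.1-fold higher number from compound 1 to compound 3 (0.06 log units; within the scatter). No measurement here explains the shift. On these data alone, whether the chloro compounds respond to the same move remains open. So does whether a 2-aminophenyl or 2-ethoxyphenyl group on that ring nitrogen would behave like 2-methoxyphenyl.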